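Chloro for fluoro on the shared core

A few compounds are considered here, and "the series" means these few. Any claim that something is new, unique, unknown or untested is made for them only; others in the source may bear on it.

Values so far in an ADME assay on MT4 cells (Homo sapiens) for cytotoxicity, read by spectrophotometry, with a stated time of 5 days (a higher number here means that more compound is tolerated, a lower number that less compound is tolerated), are:
compound 1 (`CCN(CC)CN1C(=O)/C(=N\NC(=S)NO)c2cc(Cl)ccc21`) gives 562000 nM 
compound 2 (`CCN(CC)CN1C(=O)/C(=N\NC(=S)NOC)c2cc(F)ccc21`) gives 490000 nM 

Compound 2 at 490000 nM lies within the scatter of compound 1 and neither stands apart. Compound 3 (`CCN(CC)CN1C(=O)/C(=N\NC(=S)NOC)c2cc(Cl)ccc21`) is still unmeasured and differs from compound 2 by chloro in place of fluoro on an aromatic carbon. Among the measured compounds shown here, no measured pair shows this change alone. In this assay compound 3 is expected to stay within the scatter of compound 2 because compound 1 with chloro gives 562000 nM within the scatter of compound 2. The estimated 1.0-fold higher number from compound 2 to compound 3 (0.01 log units; within the scatter) stays within the scatter. Compound 3 is expected at 500000 nM (estimated range 230000 nM to 900000 nM).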

Compound 3, half-maximal cytotoxic concentration: 454000 nM
The estimate for compound 3 lay 1.1-fold (0.04 log units) above the measured number; the measured number falls inside the stated range.
By their numbers in this assay, from the lowest: compounds 3, 2 and 1 (each within the scatter of the next).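

In this assay, chloro in place of fluoro on an aromatic carbon of the shared core now has a direct reading with the methoxy-bearing side chain held constant (a 1.1-fold lower number from compound 2 to compound 3 (0.03 log units; within the scatter)). Methyl in place of hydrogen on an oxygen also has its first reading, with chloro held constant (a 1.2-fold lower number from compound 1 to compound 3 (0.09 log units; within the scatter)). No measured evidence bears on either step.

Each change is read only once, on a single background. Going by these compounds, how bromo or an amine on that aromatic carbon, or a longer chain on the oxygen, would read in this assay stays open.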